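Phenyl on the hydrazine nitrogen of compound 1

The source may report more compounds than this note shows. Statements on the series, on what has been measured and on what is new or still open speak of the compounds shown alone.

Compound 1 `Cc1ccccc1-c1nnc(NN)s1` is the starting point. In a functional assay on the whole organism with Mus musculus as the target, with a stated time of 1 h (on this read-out higher numbers stand for an effect only at larger amounts of compound and lower numbers for an effect already at smaller amounts), compound 1 gives 30 mg/kg. Among the measured compounds shown here, the only other measured compound, compound 2 `Cc1ccccc1-c1nnc(N(N)Cc2ccccc2)s1`, gives 44 mg/kg in this assay, a number within the usual scatter of that of compound 1. Compound 3 `Cc1ccccc1-c1nnc(NNc2ccccc2)s1` differs from compound 1 by phenyl in place of hydrogen on an amine nitrogen. For the measured compounds named here, the one measured step that bears on this change, a 1.5-fold higher number from compound 1 to compound 2 (0.17 log units; within the scatter), did not move the read-out beyond the scatter, so the phenyl is expected to behave similarly, with an estimated step of a 1.2-fold higher number from compound 1 to compound 3 (0.08 log units; within the scatter). Compound 3 is therefore expected to give about 36 mg/kg in this assay, within 18 mg/kg to 72 mg/kg.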

Compound 3, dose for half-maximal effect: > 100 mg/kg
Compound 3 was reported as a limit; the forecaster's own chance of this, stated with the estimate: 10%; at least 2.7-fold (0.44 log units) between middle value and limit.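

Unlike the benzyl step, which stayed within the scatter, this change moves the read-out in this assay: phenyl in place of hydrogen on an amine nitrogen gives an at least 3.3-fold higher number from compound 1 to compound 3 (0.52 log units; beyond the scatter). So this amine nitrogen does not accept every added aromatic ring without a clear loss of effect. For compound 3 the reading is a limit, not a number: the limit of > 100 mg/kg in this assay, at which 1 of the 3 values shown sits.

The compounds shown cannot separate the effect of the group from that of its place, as benzyl and phenyl sit on different nitrogens. As far as these compounds go, it also stays open how a smaller group, such as methyl, would read on this same amine nitrogen.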